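Chain Extension on a Benzimidazole-Type Core: Lipophilicity Forecast

This account rests on a few compounds, and the source may have more. Where it says the series, first, only, none or still open, it means among the compounds named here.

Measured compounds:
compound 1, `CCCCCc1nc2ccccc2[nH]1`, 3.43
compound 2, `CCCCCCc1nc2ccccc2[nH]1`, 3.93
compound 3, `CCCc1nc2cc(C)c(C)cc2[nH]1`, 3.4

Three compounds share a fused aromatic core carrying a saturated chain, and each has been measured in a physicochemical assay for lipophilicity; a lower number here means a more polar compound, a higher number a more lipophilic compound. Compound 1 and compound 2 differ in one place only: methyl in place of hydrogen on a saturated chain carbon, five bonds along the chain from an aromatic carbon. This change gave a number 0.50 log units higher from compound 1 to compound 2 (beyond the scatter).

Compound 3 is built on a core that carries two methyl groups, and its chain is shorter. The difference between the core of compound 3 and the core of compound 1 is not broken down here. In this assay compound 3 gives 3.4, a number that sits within the scatter of the value of compound 1, while the value of compound 2 stands clearly apart from it.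

Compound 4, `CCCCc1nc2cc(C)c(C)cc2[nH]1`, has not yet been measured in this assay. It differs from compound 3 in one place: methyl in place of hydrogen on a saturated chain carbon, three bonds along the chain from an aromatic carbon. Among the measured compounds shown here, this is the same kind of change as the one from compound 1 to compound 2, but the place is not identical: there the methyl enters five bonds along the chain from an aromatic carbon, here three bonds along the chain from an aromatic carbon. Because the earlier step gave a number 0.50 log units higher from compound 1 to compound 2 (beyond the scatter), the step from compound 3 to compound 4 is expected to be of similar size, about a number 0.50 log units higher from compound 3 to compound 4 (beyond the scatter). On that basis compound 4 is estimated at 3.9, with a likely range from 3.6 to 4.2.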

Compound 4, partition coefficient: 3.9
Beside the measured number, compound 4's estimate shows no gap at the digits printed; the range from low to high includes it.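

In this assay the new step gave a number 0.50 log units higher from compound 3 to compound 4 (beyond the scatter) on the core that carries two methyl groups, and the earlier step gave a number 0.50 log units higher from compound 1 to compound 2 (beyond the scatter) on the core of compound 1, so methyl in place of hydrogen on a saturated chain carbon came out the same size on both cores at the digits printed. This shows that, within these two pairs, the size of the step carried over from one core to the other even though the place was not identical, with the methyl entering three bonds along the chain from an aromatic carbon in one pair and five bonds along it in the other, but two pairs cannot show that it would hold on every core or at every place on the chain. No measurement offered here accounts for the match between the two steps.

The compounds shown leave open whether the same step would be seen again on a longer chain, such as octyl or decyl, on either core. They also leave open what would happen if an amine or a carboxylic acid entered the chain in place of the methyl, since every step shown adds only a methyl.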